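Bromofuranone series: dibromomethyl variant of the acetylated acetal

A few compounds are considered here, and "the series" means these few. Any claim that something is new, unique, unknown or untested is made for them only; others in the source may bear on it.

Measured so far:
compound 1, `CCC[C@@H](OC(C)=O)C1=C(Br)[C@@](C)(OC)OC1=O`, 2.8 ug/mL
compound 2, `CCC[C@@H](O)C1=C(Br)/C(=C\Br)OC1=O`, 1.1 ug/mL

Both numbers come from a functional assay on KB cells (Homo sapiens) for cytotoxicity; on this read-out higher numbers stand for an effect only at larger amounts of compound and lower numbers for an effect already at smaller amounts. Compound 1 has the highest number of the two, and the nearest comparison is compound 2 at 1.1 ug/mL, a gap that falls beyond the scatter. The two compounds differ in more than one place, so the gap gives no single change to learn from.

Compound 3, `CCC[C@@H](OC(C)=O)C1=C(Br)[C@](OC)(C(Br)Br)OC1=O`, has not been measured in this assay. It differs from compound 1 in one place: dibromomethyl in place of methyl on a saturated ring carbon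

Within the data shown here, no single-change comparison between measured compounds exists in this set, so the size of the coming step cannot be read off from the numbers so far. Replacing methyl with dibromomethyl on the saturated ring carbon adds two bromine atoms at a site that otherwise stays the same; the step from compound 1 is expected to be small, within the scatter or a little below it. The expected value for compound 3 in this assay is 2 ug/mL, with a likely range from 0.7 ug/mL to 6 ug/mL, which corresponds to an estimated step of a 1.4-fold lower number from compound 1 to compound 3 (0.15 log units; within the scatter).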

Compound 3, concentration for half-maximal effect: 6.1 ug/mL
The estimate for compound 3 lay 3.1-fold (0.48 log units) below the measured number; the measured number lies above the stated range.
By their numbers in this assay, from the lowest: compound 2; then compound 1; then compound 3.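

Dibromomethyl in place of methyl on the saturated ring carbon gives the first single-change reading in this set for that position in this assay, with a 2.2-fold higher number from compound 1 to compound 3 (0.34 log units; beyond the scatter). The step is modest but beyond the scatter, so this carbon, next to the ring oxygen, is not indifferent to the group it carries, and here the change moves the read-out towards an effect only at larger amounts of compound. Among these compounds, with one step, this describes only the pair of compound 1 and compound 3, and no accompanying measurement bears on why the number rises.

As far as these compounds go, it remains open whether the shift follows the presence of bromine at all or simply the replacement of methyl by something other than methyl, a question that bromomethyl, ethyl or hydroxymethyl on the same carbon could separate. Among the compounds shown here, also open is whether the same step holds when the acetate on the side chain gives way to a free hydroxyl or a longer ester such as butyrate, since the only hydroxyl-bearing compound here differs from compound 1 in more than one place.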